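This account rests on a few compounds, and the source may have more. Where it says the series, first, only, none or still open, it means among the compounds named here.

Measured so far in a functional assay for inhibition, read by spectrophotometry, with a stated time of 20 min, tested at 3 mg/mL; a higher number here means a stronger effect of the compound at the concentration tested, a lower number a weaker effect:
compound 1, `CC(=O)c1ccc(NC(=O)C(CC(C)C)N(C(=O)c2ccccc2)S(=O)(=O)c2ccc(C)cc2)cc1`: 63.1%
compound 2, `CC(=O)c1ccc(NC(=O)C(CC(C)C)N(C(=O)c2ccccc2)S(=O)(=O)c2ccc([N+](=O)[O-])cc2)cc1`: 62.3%
compound 3, `CC(=O)c1ccc(NC(=O)CN(C(=O)c2ccccc2)S(=O)(=O)c2ccccc2)cc1`: 40.7%

Compound 3 stands lowest of the three numbers in this assay; its gap to compound 2, the nearest, and to compound 1, the furthest, both lie beyond the scatter. Compound 4, `CC(=O)c1ccc(NC(=O)C(CC(C)C)N(C(=O)c2ccccc2)S(=O)(=O)c2ccccc2)cc1`, differs from compound 3 in one place: isobutyl in place of hydrogen on a saturated chain carbon bound to an amide-type nitrogen and a carbonyl carbon. Among the compounds with values here, no single measured step covers this change. Compound 3 differs from compound 1 and from compound 2 in two places, the isobutyl and the substituent on the aromatic carbon of the sulfonyl ring, and their values show that both compounds carrying the isobutyl sit well above compound 3. Within the data shown here, the only measured step, a number 0.8 percentage points lower from compound 1 to compound 2 (within the scatter), shows that the substituent on that ring contributes little, which leaves the isobutyl as the remaining difference between compound 3 and the two higher compounds. In this assay a rise beyond the scatter is therefore expected on going from compound 3 to compound 4, a number 19.3 percentage points higher from compound 3 to compound 4 (beyond the scatter). Compound 4 is estimated at 60%, with a range from 47% to 71%.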

Compound 4, a percentage reported as inhibition, at one concentration (the size of the read-out at that concentration, not a potency): 40.7%
Compound 4: the middle estimate sits 19.3 percentage points above what was measured; the measured number lies below the stated range.
By their numbers in this assay, from the lowest: compounds 3 and 4 (each within the scatter of the next); then compounds 2 and 1 (each within the scatter of the next).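

In this assay, isobutyl in place of hydrogen on the saturated chain carbon bound to an amide-type nitrogen and a carbonyl carbon gives no change at the digits printed from compound 3 to compound 4 (within the scatter) when the sulfonyl ring carries only hydrogen. With the isobutyl held in place, the aromatic carbon proves to be a sensitive position, since replacing nitro with hydrogen gives a number 21.6 percentage points lower from compound 2 to compound 4 (beyond the scatter) and replacing methyl with hydrogen gives a number 22.4 percentage points lower from compound 1 to compound 4 (beyond the scatter) in this series. No measurement shown here accounts for these steps.

On these data alone, it remains open whether isobutyl also leaves the read-out unchanged when methyl or nitro sits on the aromatic carbon. Also open, as far as these compounds go, is how a methoxy group, a chlorine atom or an amine on that carbon, or a longer chain in place of isobutyl, would read.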